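The compounds below may be only part of what the source reports. "The series", "measured", "known", "first", "only" and "open" are said of these compounds alone.

Measured so far:
compound 1, `Cc1nn(-c2ccccn2)c2cc(-c3ccc(CCCC(=O)O)cc3)ccc12`, 2100 nM
compound 2, `COc1cc(CCC(=O)O)ccc1-c1ccc2c(C)nn(-c3ccccn3)c2c1`, 8200 nM

Both were tested in a functional assay on cells for agonist activity at Free fatty acid receptor 1 (Mus musculus), read by FLIPR and calcium flux, with a stated time of 5 min; on this read-out higher numbers stand for an effect only at larger amounts of compound and lower numbers for an effect already at smaller amounts. Compound 1 gives 2100 nM, while compound 2 gives 8200 nM, the higher of the two numbers; the gap between them lies beyond the scatter. Compound 3, `Cc1nn(-c2ccccn2)c2cc(-c3ccc(CCC(=O)O)cc3Cl)ccc12`, differs from compound 2 by one change: chloro in place of methoxy on an aromatic carbon. Within the data shown here, no measured pair shows this exact change, so its effect is open. Since compound 2 sits at the higher number with 8200 nM, a moderate fall is expected, a 2.1-fold lower number from compound 2 to compound 3 (0.31 log units; beyond the scatter). Compound 3 is therefore estimated at 4000 nM, with a likely range of 1200 nM to 13000 nM.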

Compound 3, half-maximal effective concentration: 1200 nM
Estimate against measurement, compound 3: 3.3-fold (0.52 log units) above; measured number inside the range.
By their numbers in this assay, from the lowest: compounds 3 and 1 (each within the scatter of the next); then compound 2.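

On the aromatic carbon ortho to a large group, chloro in place of methoxy gives a 6.8-fold lower number from compound 2 to compound 3 (0.83 log units; beyond the scatter) in this assay, so what sits at this position clearly changes the response. This is one pair, and it shows the size of this single swap only. Nothing available gives a reason for the step. Going by these compounds, whether fluoro or a nitrile at this same carbon would shift the number further stays open. So does whether chloro would act alike on the longer acid chain of compound 1.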